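Methoxy Out, Pyrrolidinyl In: Estimating the Next Response

This account rests on a few compounds, and the source may have more. Where it says the series, first, only, none or still open, it means among the compounds named here.

Measured so far:
Compound 1, `CCCc1nnc2c(C#N)c(N3CCC(c4ccccc4)CC3)ccn12`: 272%
Compound 2, `N#Cc1c(N2CCC(c3ccccc3)CC2)ccn2c(CC(F)(F)F)nnc12`: 277%
Compound 3, `COCc1nnc2c(C#N)c(N3CCC(c4ccccc4)CC3)ccn12`: 196%

In a functional assay on CHO cells for positive allosteric modulation of metabotropic glutamate receptor 2 (Homo sapiens), read by GTPgammaS binding, with a stated time of 30 min (a lower number here means a smaller maximal response, a higher number a larger maximal response), compound 3 gives 196%, the lowest of the three numbers. The step from the propyl-bearing analogue is a number 76 percentage points lower from compound 1 to compound 3 (beyond the scatter), and from the trifluoroethyl-bearing analogue it is a number 81 percentage points lower from compound 2 to compound 3 (beyond the scatter). Those two larger analogues sit close together: the step is a number 5 percentage points higher from compound 1 to compound 2 (within the scatter).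

Compound 4, `N#Cc1c(N2CCC(c3ccccc3)CC2)ccn2c(CN3CCCC3)nnc12`, changes the same spot again: pyrrolidin-1-yl in place of methoxy on a saturated chain carbon bound to an aromatic carbon. Both large measured steps involve the methoxy that now leaves, and both ran downward when it entered. Going by the values given here, that is the only evidence bearing on the new step. Among the compounds with values here, the pyrrolidin-1-yl that enters has no measured counterpart here, so its own contribution is unknown, and the expectation rests on the methoxy leaving.

The expected direction is upward, toward the range of compound 1 and compound 2, though with wide uncertainty. Compound 4 is estimated at 240%, with a range from 180% to 300%. This estimate corresponds to an expected step of a number 44 percentage points higher from compound 3 to compound 4 (beyond the scatter).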

Compound 4, largest response reached (Emax), in percent of the reference or control that the assay uses: 240%
Compound 4: middle estimate and measured number agree at the digits printed; measured number inside the range.
By their numbers in this assay, from the lowest: compound 3; then compound 4; then compounds 1 and 2 (each within the scatter of the next).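

In this assay, pyrrolidin-1-yl in place of methoxy on a saturated chain carbon bound to an aromatic carbon gives a number 44 percentage points higher from compound 3 to compound 4 (beyond the scatter) and so shows that this place can carry a ring and still give a response well clear of the low end of the series. The ring does not reach the top level, however: pyrrolidin-1-yl in place of trifluoromethyl gives a number 37 percentage points lower from compound 2 to compound 4 (beyond the scatter) and in place of ethyl gives a number 32 percentage points lower from compound 1 to compound 4 (beyond the scatter) and so the four compounds fall on three separate levels at this one place, not the two seen before. Nothing measured here accounts for the middle position of compound 4.

The compounds shown leave open whether the response at this place follows the ring itself or the nitrogen attached to the chain carbon, a question that an open-chain amine such as dimethylamino, or a piperidin-1-yl ring, would help to separate. Also open, as far as these compounds go, is how a longer chain such as butyl would compare with the propyl of compound 1.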